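Replacing the benzofuranyl group of compound 3 with ethynyl

This account rests on a few compounds, and the source may have more. Where it says the series, first, only, none or still open, it means among the compounds named here.

Three nucleoside analogues carry numbers in an ADME assay on MRC5 cells (Homo sapiens), read by MTT assay, with a stated time of 72 h (a higher number here means a weaker inhibitor, a lower number a stronger inhibitor), so far. Compound 1 `Nc1nc(N)c2c(-c3cc4ccccc4o3)cn([C@@H]3O[C@H](CO)[C@@H](O)[C@H]3O)c2n1` gives 78500 nM in this assay. Compound 2 `COc1ncnc2c1c(I)cn2[C@@H]1O[C@H](CO)[C@@H](O)[C@H]1O` gives 63000 nM in this assay. Compound 3 `Cc1nc(N)c2c(-c3cc4ccccc4o3)cn([C@@H]3O[C@H](CO)[C@@H](O)[C@H]3O)c2n1` gives 91800 nM in this assay, the highest of the three numbers, though its gaps to compound 1 and to compound 2 both lie within the scatter. Among the measured compounds shown here, the one single-point step so far, a 1.2-fold higher number from compound 1 to compound 3 (0.07 log units; within the scatter), changes the number only within the scatter.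

Compound 4 `C#Cc1cn([C@@H]2O[C@H](CO)[C@@H](O)[C@H]2O)c2nc(C)nc(N)c12` has not yet been measured in this assay. It differs from compound 3 at one place: ethynyl in place of 1-benzofuran-2-yl on an aromatic carbon. For the measured compounds named here, no measured pair in the set shows this change, so nothing here speaks to its size or direction; the only measured step concerns a different position and was within the scatter. Going by the values given here, the three numbers so far sit close together across quite different substituents at this position and at the six-membered ring, which argues for a number of the same order.

Compound 4 is therefore expected to give about 80000 nM in this assay. The step this implies, a 1.1-fold lower number from compound 3 to compound 4 (0.06 log units; within the scatter), is expected to stay within or near the scatter. The estimated range for compound 4 runs from 30000 nM to 200000 nM; no step of this kind has been measured, and the range is kept wide for that reason.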

Compound 4, half-maximal inhibitory concentration: > 100000 nM
Compound 4 ended at the assay's limit (the forecaster's own chance of this, stated with the estimate: 20%); at least 1.2-fold (0.09 log units) between middle value and limit.
By their numbers in this assay, from the lowest: compounds 2, 1 and 3 (each within the scatter of the next). At a limit, above all of these: compound 4.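

Among the compounds shown here, replacing 1-benzofuran-2-yl with ethynyl on this aromatic carbon gives the first direct reading of a change at this position in this assay: the step is an at least 1.0-fold higher number from compound 3 to compound 4 (0.03 log units; that floor lies within the scatter). From the compounds shown here alone, compound 4 sits at a limit of the assay, so the true size of this step stays unknown: the limit of > 100000 nM in this assay, at which 1 of the 4 values shown sits. Loss of the ringed 1-benzofuran-2-yl in favour of ethynyl therefore gives no lower number here, and the floor allows compound 4 to lie anywhere from within the scatter of compound 3 upward.

Going by these compounds, whether an amine, a carboxylic acid or a longer alkyl chain on this aromatic carbon would give a number inside the assay's range remains open. Also open, on these data alone, is what ethynyl gives on the core of compound 1, which carries amino in place of methyl.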